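The source may report more compounds than this note shows. Statements on the series, on what has been measured and on what is new or still open speak of the compounds shown alone.

In an ADME assay on MRC5 cells (Homo sapiens) for inhibition, with a stated time of 72 h (a higher number here means that more compound is needed for the effect, a lower number that less compound is needed), two compounds with the shared core have been measured so far. Compound 1 (`COc1cccc(OC)c1C(=O)Nc1c[nH]nc1C(=O)NCCCOC(C)C`) returns > 50000 nM as its reading, which is a limit of the assay and not a number. Within the data shown here, compound 2 (`COc1cccc(OC)c1C(=O)Nc1c[nH]nc1C(=O)NC1CCC(C)CC1`) gives 45000 nM and so holds the only actual number available. Among the measured compounds shown here, the one measured step is an at least 1.1-fold lower number from compound 1 to compound 2 (0.04 log units; that floor lies within the scatter) and its size is only a floor, set by the limit of > 50000 nM in this assay, at which 1 of the 2 values shown sits, and not a true difference. Compound 3 (`COc1cccc(OC)c1C(=O)Nc1c[nH]nc1C(=O)Nc1ccncc1`) changes the same kind of amide-type nitrogen, with pyridin-4-yl in place of 4-methylcyclohexyl (pyridin-4-yl in place of 4-methylcyclohexyl on an amide-type nitrogen). For the measured compounds named here, no measured step places an aromatic ring on this nitrogen, so that single step is the only guide, and it is a weak one. Going by the values given here, the expectation in this assay is therefore no step beyond the scatter in either direction, resting on the small size of an at least 1.1-fold lower number from compound 1 to compound 2 (0.04 log units; that floor lies within the scatter) as the sole precedent. The estimated change is a 1.1-fold lower number from compound 2 to compound 3 (0.05 log units; within the scatter) and it is expected to be minor. For compound 3 the expected value is 40000 nM with an estimated range from 15000 nM to 70000 nM and an outcome at the limit of the assay is expected to be about as likely as a number.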

Compound 3, half-maximal effective concentration: > 50000 nM
Compound 3: only a limit was reported; the forecaster's own chance of this, stated with the estimate: 50%; middle value at least 1.2-fold (0.09 log units) away from the limit.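

In this assay compound 3 gives > 50000 nM, which is a limit of the assay and not a number. The step to it is an at least 1.1-fold higher number from compound 2 to compound 3 (0.04 log units; that floor lies within the scatter), so the change from a non-aromatic carbon ring to an aromatic ring with a hetero atom has no measured size beyond a floor, and the step between compound 1 and compound 3 cannot be read. This position now holds a chain, a non-aromatic ring and an aromatic ring, and these three different groups on the amide-type nitrogen give no reading that stands clearly apart from the others, though that comparison is capped: the limit of > 50000 nM in this assay, at which 2 of the 3 values shown sit.

Going by these compounds, what a plain phenyl ring, a carboxylic acid or an amine on a longer chain would give on this nitrogen remains open. Also open, on these data alone, is whether any group here can bring the number well clear of the limit, which would give steps of readable size.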